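Nitrofuran amides on cytotoxicity toward Vero cells

The compounds below may be only part of what the source reports. "The series", "measured", "known", "first", "only" and "open" are said of these compounds alone.

Measured so far:
compound 1 `O=C(Nc1nc(-c2cccc(Br)c2)cs1)c1ccc([N+](=O)[O-])o1`: 71000 nM
compound 2 `O=C(Nc1nc(-c2cccc(C(F)(F)F)c2)cs1)c1ccc([N+](=O)[O-])o1`: 23900 nM

Compound 2 holds the lowest of the two numbers in an ADME assay on Vero cells (Chlorocebus sabaeus) for cytotoxicity, read by MTT assay, with a stated time of 72 h; a higher number here means a weaker inhibitor, a lower number a stronger inhibitor; compound 1 stands above it by a 3.0-fold lower number from compound 1 to compound 2 (0.47 log units; beyond the scatter), a modest step that lies beyond the scatter. Compound 3 `CCOc1cccc(-c2csc(NC(=O)c3ccc([N+](=O)[O-])o3)n2)c1` is the next member to be measured. It differs from compound 2 by ethoxy in place of trifluoromethyl on an aromatic carbon. Among the compounds with values here, no measured step involves an ethoxy group, so the only step in hand, that from bromo to trifluoromethyl, bears on it indirectly at best: it shows that a change of the substituent at this position can move this assay by a modest amount, without telling which way a third group goes. On that basis a step of no more than modest size is expected for a 1.3-fold higher number from compound 2 to compound 3 (0.13 log units; within the scatter), with no clear direction. Compound 3 is therefore estimated at 32000 nM, within a range from 12000 nM to 85000 nM.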

Compound 3, half-maximal inhibitory concentration: > 90000 nM
Compound 3: only a limit was reported; the forecaster's own chance of this, stated with the estimate: 10%; at least 2.8-fold (0.44 log units) between middle value and limit.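

In this assay compound 3 gives only a limit, > 90000 nM. The step of ethoxy in place of trifluoromethyl on this aromatic carbon is an at least 3.7-fold higher number from compound 2 to compound 3 (0.57 log units; beyond the scatter), so the earlier finding of a modest move at this position now has a direction for a third group: this change raises the number, and by no less than a modest amount. Against bromo the reading is an at least 1.2-fold higher number from compound 1 to compound 3 (0.10 log units; that floor lies within the scatter), so no order between ethoxy and bromo can be claimed, and compound 2 alone stands apart from the other two.

From the compounds shown here alone, how far the true value of compound 3 lies past its limit remains unknown. Also open, going by these compounds, is whether an amine, a carboxylic acid or an alkoxy chain longer than ethoxy on the same carbon would fall nearer trifluoromethyl or nearer ethoxy.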